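This account rests on a few compounds, and the source may have more. Where it says the series, first, only, none or still open, it means among the compounds named here.

Measured in an assay on CHO cells for displacement of a labelled ligand from adenosine receptor A3 (Homo sapiens), read by scintillation counting, with a stated time of 45 min, tested at 1 uM, in the presence of a further agent that is not named here; a lower number here means less inhibition, a higher number more inhibition at the concentration tested (going by the name of the read-out):
compound 1 `CCCn1c(=O)[nH]c2nc(-c3ccc(S(=O)(=O)N4CCN(c5ccccc5Cl)CC4)cc3)[nH]c2c1=O`: 32%
compound 2 `CCCn1c(=O)[nH]c2nc(-c3ccc(S(=O)(=O)N4CCN(c5ccc(Cl)cc5F)CC4)cc3)[nH]c2c1=O`: 14%
compound 3 `CCCn1c(=O)[nH]c2nc(-c3ccc(S(=O)(=O)N4CCN(Cc5cccc(Br)c5)CC4)cc3)[nH]c2c1=O`: 23%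

Compound 3 stands second highest of the three numbers, but its gaps to compound 1 and to compound 2 are both within the scatter, so no order among the three is claimed. Compound 4 `CCCn1c(=O)[nH]c2nc(-c3ccc(S(=O)(=O)N4CCN(c5ccccc5F)CC4)cc3)[nH]c2c1=O` follows from compound 3 by 2-fluorophenyl in place of 3-bromobenzyl on an amine nitrogen in a ring. The step that bears most directly on this is the reverse exchange a number 9 percentage points lower from compound 1 to compound 3 (within the scatter), which stayed within the scatter; a number 9 percentage points higher from compound 2 to compound 3 (within the scatter) likewise stayed within the scatter. Only a number 18 percentage points lower from compound 1 to compound 2 (beyond the scatter) moved the number beyond the scatter, and that step changed the halogen pattern on a phenyl ring rather than removing or adding a benzyl linker. Compound 4 carries a 2-fluorophenyl, the closest counterpart among the measured compounds being the 2-chlorophenyl of compound 1, for which no step to compound 4 is shown. The expectation is therefore a small step, a number 5 percentage points higher from compound 3 to compound 4 (within the scatter), not beyond the scatter, toward the number of compound 1. Compound 4 is estimated at 28%, range 12% to 44%.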

Compound 4, a percentage reported as inhibition, at one concentration (the size of the read-out at that concentration, not a potency): 9%
Estimate against measurement, compound 4: 19 percentage points above, and the stated range ends above it.
By their numbers in this assay, from the lowest: compounds 4, 2, 3 and 1 (each within the scatter of the next, the first and the last beyond it).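

In this assay, fluoro in place of chloro on an aromatic carbon (going a number 23 percentage points lower from compound 1 to compound 4 (beyond the scatter)) shows that exchanging one halogen on the aryl group at this amine nitrogen can move the read-out beyond the scatter. Hydrogen in place of chloro stays within the scatter (going a number 5 percentage points lower from compound 2 to compound 4 (within the scatter)), while 2-fluorophenyl in place of 3-bromobenzyl passes beyond it (going a number 14 percentage points lower from compound 3 to compound 4 (beyond the scatter)), unlike the matching exchange with 2-chlorophenyl (going a number 9 percentage points lower from compound 1 to compound 3 (within the scatter)), so the outcome of the benzyl-to-aryl exchange depends on the halogen carried by the aryl group. No measurement shown here accounts for these steps.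

Still open, going by these compounds, is how an unsubstituted phenyl, a 2-bromophenyl or a 2-methoxyphenyl would read at this position. Also open, on these data alone, is how an unsubstituted benzyl or a 3-fluorobenzyl would compare with 3-bromobenzyl.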